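A few compounds are considered here, and "the series" means these few. Any claim that something is new, unique, unknown or untested is made for them only; others in the source may bear on it.

Measured so far in an ADME assay on cells (Mus musculus, strain BALB/C) for cytotoxicity, read by MTT assay, with a stated time of 24 h; on this read-out lower numbers stand for higher toxicity in this test and higher numbers for lower toxicity in this test:

- compound 1 `Cc1ccc(C(=O)N/N=C/c2ccccc2O)c(O)c1`: 761000 nM
- compound 2 `Cc1ccc(C(=O)N/N=C/c2ccc(Cl)cc2Cl)c(O)c1`: 291000 nM

Compound 2 stands at the lower of the two numbers in this assay, that is, it is the more toxic of the pair; compound 1 gives a higher number, and the gap between the two lies beyond the usual scatter. Within the data shown here, no step between compounds differing in one place is available among the measured pair, so only these two values frame the series.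

Compound 3 `Cc1ccc(C(=O)N/N=C/c2ccccc2Cl)c(O)c1` is unmeasured in this assay. It differs from compound 2 as follows: hydrogen in place of chloro on an aromatic carbon. The remaining change-bearing substituent of compound 3, a single chloro on the ring, sits between the two-chloro pattern of compound 2 and the chloro-free ring of compound 1, which motivates a mild upward move.

An estimated step from compound 2 to compound 3 of a 1.4-fold higher number from compound 2 to compound 3 (0.16 log units; within the scatter) is expected, modest and at the edge of the scatter, toward a higher number. Compound 3 is therefore expected to give about 420000 nM in this assay, within a range of 200000 nM to 850000 nM.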

Compound 3, half-maximal cytotoxic concentration: 125000 nM
For compound 3 the middle estimate is 3.4-fold (0.53 log units) above the measured one; measured number below the stated range.
By their numbers in this assay, from the lowest: compound 3; then compound 2; then compound 1.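

Read in this assay, the chloro para to a large group does not push the number down: with hydrogen in its place there is a 2.3-fold lower number from compound 2 to compound 3 (0.37 log units; beyond the scatter), so this change goes toward higher toxicity in this test, and losing this chloro does not relieve it. At the other changed carbon, chloro in place of hydroxy gives a 6.1-fold lower number from compound 1 to compound 3 (0.78 log units; beyond the scatter), so both single-place steps end at compound 3, which holds the lowest number of the three, with both steps beyond the usual scatter. Nothing at hand gives a measured reason for either step.

Going by these compounds, whether the effect of the hydrogen-for-chloro change belongs to chlorine in particular stays open, since a fluoro, a methoxy or an amine on that same aromatic carbon could land on either side of compound 2. Also open, on these data alone, is whether the step from compound 1 reflects the arrival of the chloro or the departure of the hydroxy, a question that a methyl on that carbon could help to separate.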